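The source may hold more compounds than are shown below. What is called first, only, known or untested is meant among the compounds shown, and "the series" means these compounds.

Compound 1 `COc1ccc(CNc2nc([Se]C)nc3ccccc23)cc1` is the point of departure. In a functional assay on CCRF-CEM cells (Homo sapiens) for cytotoxicity, read by MTT assay, with a stated time of 72 h (a lower number here means that less compound is tolerated, a higher number that more compound is tolerated), compound 1 gives > 100000 nM, which is a limit of the assay rather than a number. Compound 2 `COc1ccc(CNc2nc([SeH])nc3ccccc23)cc1` differs from compound 1 by hydrogen in place of methyl on a selenium. In this assay compound 2 also gives > 100000 nM, again a limit. The step that the two limits leave unreadable from compound 1 to compound 2 is therefore not readable, as both values sit at the limit of > 100000 nM in this assay, at which 2 of the 3 values shown sit. Going by the values given here, compound 3 `CCCCC[Se]c1nc(N)c2cccnc2n1` carries a different core and a pentyl chain on the selenium, and in this assay compound 3 gives 72600 nM, the only numerical value among the three. Compound 4 `C[Se]c1nc(NCc2ccccc2)c2ccccc2n1` differs from compound 1 by hydrogen in place of methoxy on an aromatic carbon. Among the compounds with values here, no measured step bears on this change: the one step measured, from compound 1 to compound 2, touches the selenium substituent and is unreadable, and compound 3 shares neither the core nor the benzyl portion of compound 1. With compound 1 at a limit, no direction can be read in this assay, and the expectation is that compound 4 stays at or near that limit. Compound 4 is accordingly estimated at 120000 nM (range 40000 nM to 300000 nM), which means an expected step that the limit leaves unreadable from compound 1 to compound 4. Most likely the assay again returns only a limit for compound 4.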

Compound 4, concentration lethal to 50% of the cells: 83500 nM
Beside the measured number, compound 4's estimate is 1.4-fold (0.16 log units) above it; the measured number falls inside the stated range.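

Hydrogen in place of methoxy on the aromatic carbon, para to a large group, gives an at least 1.1-fold lower number from compound 1 to compound 4 (0.07 log units; that floor lies within the scatter) in this assay. Going by these compounds alone, this is the first step at this position, and, unlike the selenium step between compound 1 and compound 2, it has a readable direction, with compound 4 returning a number rather than a limit. Only a floor can be given, however, and it does not establish a real change on removal of the methoxy, as compound 1 remains a limit: the limit of > 100000 nM in this assay, at which 2 of the 4 values shown sit.

On these data alone, what an amine, a hydroxyl or a chlorine on this aromatic carbon would do stays open, as does the true size of the step from methoxy to hydrogen. Also open, as far as these compounds go, is whether the same change would read alike with a longer chain on the selenium, such as the pentyl of compound 3, or with hydrogen on the selenium, as in compound 2.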